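Carbamoyl to methoxycarbonyl: the step to compound 3

The source may report more compounds than this note shows. Statements on the series, on what has been measured and on what is new or still open speak of the compounds shown alone.

Two compounds have numbers in a functional assay on L1210 cells (Mus musculus) for antiproliferative activity; a higher number here means a more potent compound, by a factor of ten per unit of this negative logarithm, a lower number a less potent compound. Compound 1 `Cc1nc(/N=N/N(C)C)c(C(N)=O)[nH]1` gives 3.06. Compound 2 `CN(C)/N=N/c1n[nH]cc1C(N)=O` gives 3.49, the higher of the two numbers, with compound 1 standing lower by a gap beyond the usual scatter. Compound 3 `COC(=O)c1c[nH]nc1/N=N/N(C)C` differs from compound 2 by methoxy in place of amino on a carbonyl carbon, carbamoyl to methoxycarbonyl on a carbonyl carbon whose other neighbour is an aromatic carbon. Within the data shown here, no measured pair shows this change, so its size is untested here. The expected step, a number 0.19 log units lower from compound 2 to compound 3 (within the scatter), is small, within the scatter or slightly downward. Compound 3 is therefore estimated at 3.3, in a range from 2.7 to 3.9.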

Compound 3, logarithm of the reciprocal of the active concentration, log(1/C): 3.49
The estimate for compound 3 lay 0.19 log units below the measured number; the measured number falls inside the stated range.
By their numbers in this assay, from the lowest: compound 1; then compounds 2 and 3 (each within the scatter of the next).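

In this assay, methoxy in place of amino on a carbonyl carbon gives no change at the digits printed from compound 2 to compound 3 (within the scatter). Among these compounds, this is the first reading of any change at this place: amino can be exchanged for methoxy without a shift beyond the scatter, though this rests on one pair alone. No measurement available here bears on why the two groups read alike.

Still open, on these data alone, is whether a carboxylic acid or a longer ester chain at this place would read the same. Also open, as far as these compounds go, is whether this change behaves alike on the core of compound 1.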